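From methyl to pyridin-2-yl on the ring nitrogen

The source may hold more compounds than are shown below. What is called first, only, known or untested is meant among the compounds shown, and "the series" means these compounds.

In a functional assay on C-33-A cells (Homo sapiens) for antiproliferative activity, read by MTT assay (on this read-out higher numbers stand for weaker inhibition and lower numbers for stronger inhibition), compound 3 `CN1CCN(c2nc(-n3ccc4ccccc43)c3ccccc3n2)CC1` gives 11.5 ug/mL, and compound 2 `c1ccc2c(c1)ccn2-c1nc(N2CCNCC2)nc2ccccc12` gives 8.2 ug/mL. The difference between them is a 1.4-fold higher number from compound 2 to compound 3 (0.15 log units; within the scatter), so hydrogen and methyl on the amine nitrogen cannot be told apart here. Compound 1 `Fc1ccc(N2CCN(c3nc(-n4ccc5ccccc54)c4ccccc4n3)CC2)cc1`, which carries 4-fluorophenyl at that nitrogen, gives 50 ug/mL. Compound 3 therefore stands level with compound 2 and well under compound 1.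

Compound 4 `c1ccc(N2CCN(c3nc(-n4ccc5ccccc54)c4ccccc4n3)CC2)nc1` puts pyridin-2-yl in place of methyl on the same amine nitrogen: pyridin-2-yl in place of methyl on an amine nitrogen in a ring. Going by the values given here, no measured compound carries pyridin-2-yl, so the nearest guide is the one measured compound with a six-membered aromatic ring at this nitrogen. Two steps lead away from compound 1, namely a 4.3-fold lower number from compound 1 to compound 3 (0.64 log units; beyond the scatter) and a 6.1-fold lower number from compound 1 to compound 2 (0.79 log units; beyond the scatter). Both are modest and beyond the scatter, and both run towards stronger inhibition as the 4-fluorophenyl group leaves. Run in reverse, they suggest that adding the new ring should weaken inhibition, although this rests on compound 1 alone, and pyridin-2-yl may not match 4-fluorophenyl in full. In this assay the step expected for compound 4 is a 2.6-fold higher number from compound 3 to compound 4 (0.42 log units; beyond the scatter), a modest rise in the number. The estimate for compound 4 is 30 ug/mL, within an expected range of 12 ug/mL to 70 ug/mL.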

Compound 4, half-maximal inhibitory concentration: 50 ug/mL
The estimate for compound 4 lay 1.7-fold (0.22 log units) below the measured number; the range from low to high includes it.
By their numbers in this assay, from the lowest: compounds 2 and 3 (each within the scatter of the next); then compounds 1 and 4 (each within the scatter of the next).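

In this assay, exchanging 4-fluorophenyl for pyridin-2-yl on the amine nitrogen in a ring gives no change at the digits printed from compound 1 to compound 4 (within the scatter) between two compounds that differ in this one place, so the hetero atom and hydrogen-bond acceptor that enter with pyridin-2-yl bring no difference that can be read here. The earlier rise in the number rested on compound 1 alone, but it now has a second example, with a 4.3-fold higher number from compound 3 to compound 4 (0.64 log units; beyond the scatter) and a 6.1-fold higher number from compound 2 to compound 4 (0.79 log units; beyond the scatter) as modest steps beyond the scatter. At this position the four compounds therefore fall into two groups, with hydrogen and methyl in compound 2 and compound 3 at the lower numbers, and the six-membered aromatic rings in compound 1 and compound 4 at the higher numbers, and none of the four goes against this split.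

No supporting measurement accompanies these numbers, and the reason for the split remains unknown. On these data alone, it also remains open whether a saturated cyclohexyl ring, a benzyl group or a longer alkyl chain on this nitrogen would fall with methyl or with the aromatic rings.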